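Replacing ethyl with hydrogen on compound 2

The compounds below may be only part of what the source reports. "The series", "measured", "known", "first", "only" and "open" are said of these compounds alone.

In a functional assay on MCF7 cells (Homo sapiens) for antiproliferative activity, read by sulforhodamine B assay, with a stated time of 72 h (a higher number here means a weaker inhibitor, a lower number a stronger inhibitor), compound 2 `CCN1C(=O)CS/C1=N/Nc1nncc2ccccc12` gives 98 nM and stands within the scatter of compound 1 `O=C1CS/C(=N/Nc2nncc3ccccc23)N1c1ccccc1` at 77 nM in the same assay. Compound 3 `Cc1cc(C)nc(NS(=O)(=O)c2ccc(Nc3nncc4ccccc34)cc2)n1` stands apart from both, with a value of 7.7 nM that lies beyond the scatter of compound 2. It carries a different group on the shared core, so it says little about the change considered here.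

The change from compound 2 to compound 4 `O=C1CS/C(=N/Nc2nncc3ccccc23)N1` is hydrogen in place of ethyl on an amide-type nitrogen in a ring. For the measured compounds named here, one measured step bears on it (a 1.3-fold higher number from compound 1 to compound 2 (0.10 log units; within the scatter)), which is ethyl in place of phenyl on an amide-type nitrogen in a ring. That single pair shows no change beyond the scatter in this assay when the group on this nitrogen is exchanged. Going by the values given here, no measured compound has hydrogen there, however, so the evidence is thin and the range must stay wide. No step beyond the scatter is expected, and the estimated step (a 1.1-fold higher number from compound 2 to compound 4 (0.05 log units; within the scatter)) is correspondingly small. The expected value for compound 4 is 110 nM within an estimated range (35 nM to 330 nM).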

Compound 4, half-maximal inhibitory concentration: 89 nM
The estimate for compound 4 lay 1.2-fold (0.09 log units) above the measured number; measured number inside the range.
By their numbers in this assay, from the lowest: compound 3; then compounds 1, 4 and 2 (each within the scatter of the next).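

In this assay the step from ethyl to hydrogen, a 1.1-fold lower number from compound 2 to compound 4 (0.04 log units; within the scatter), lies within the scatter, and so does the step from phenyl to hydrogen, a 1.2-fold higher number from compound 1 to compound 4 (0.06 log units; within the scatter), on the same amide-type nitrogen in a ring. For the compounds shown here, the earlier pair had compared only two carbon groups at this nitrogen; with hydrogen added, the three compounds now span an unsubstituted nitrogen, a small alkyl group and an aromatic ring, all within the scatter of each other, so in this assay neither ethyl nor phenyl is required there for the activity seen with the shared core. Nothing in the available data gives a reason for this lack of response.

What the compounds shown leave open is whether this tolerance extends beyond hydrogen, ethyl and phenyl, for instance to a longer alkyl chain, a chain ending in an amine or a carboxylic acid on this nitrogen. They also leave open whether the same lack of response would appear on other cell lines, since all three values come from a single assay.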